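Same Atoms, Joined Differently, in Compound 1

The source may hold more compounds than are shown below. What is called first, only, known or untested is meant among the compounds shown, and "the series" means these compounds.

Compound 1 (`O=C(NCc1ccc(S(=O)(=O)N2CCCCC2)cc1)c1cc2cnccc2s1`) has no single number in an ADME assay on microsomes from liver (Mus musculus) for metabolic stability, read by LC-MS, with a stated time of 30 min, tested at 1 uM (on this read-out lower numbers stand for a less stable compound and higher numbers for a more stable compound), and its entry reads "below limit of detection" (no number reported). Compound 2 (`Cn1c(C(=O)NCc2ccc(S(=O)(=O)c3ccccc3)cc2)cc2ccncc21`) also has no number, with the entry "below limit of detection" (no number reported). Among the measured compounds a number appears only for compound 3 (`O=C(NCc1ccc(S(=O)(=O)c2cc(F)cc(F)c2)cc1)c1cc2cnccc2[nH]1`) with 63% as its percent remaining. No two of these compounds differ in one place only, so the data hold no measured step to draw on.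

The next compound is compound 4 (`O=C(NCc1ccc(S(=O)(=O)N2CCCCC2)cc1)c1cc2cccnc2s1`) which has the same atoms as compound 1, joined differently. The change is a group of 9 heavy atoms (7 carbon, 1 nitrogen, 1 sulfur; one five-membered aromatic ring with 1 hetero atom, one six-membered aromatic ring with 1 hetero atom) in place of a group of 9 heavy atoms (7 carbon, 1 nitrogen, 1 sulfur; one five-membered aromatic ring with 1 hetero atom, one six-membered aromatic ring with 1 hetero atom), on a carbonyl carbon and the rest of compound 1 stays as it was. In this assay a step of modest size is expected, toward a more stable compound if it moves at all, and quite possibly none beyond the scatter. The nearest reference remains compound 1 with "below limit of detection" (no number reported), so a second entry without a number is a real possibility. Compound 4 is estimated at 6% with an expected range from 1% to 25% in this measurement.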

Compound 4, percent of the compound remaining: "below limit of detection" (no number reported)
For compound 4 the study gives words and no number; no gap can be computed for the estimate.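

Compound 1 and compound 4 both carry entries without a number in this assay, so no step can be read between them. Nothing shown offers an explanation for this shared outcome. The compounds shown leave open whether joining the same atoms differently changes the percent remaining at all, since neither compound has a number to compare.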